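Swapping a phenyl for a pyridyl on a thienopyrimidine amine

This account rests on a few compounds, and the source may have more. Where it says the series, first, only, none or still open, it means among the compounds named here.

Measured compounds:
Compound 1 `C/C=C/C(=O)Nc1cccc(Oc2nc(Nc3cccc(OC)c3)nc3ccsc23)c1`: 14600 nM
Compound 2 `COc1cccc(Nc2nc(Oc3cccc(NC(=O)/C=C/C(C)C)c3)c3sccc3n2)c1`: 43900 nM

Both compounds were tested in a functional assay on MCF7 cells (Homo sapiens) for inhibition, read by MTT assay, with a stated time of 72 h; a higher number here means a weaker inhibitor, a lower number a stronger inhibitor. Going by the values given here, compound 2 holds the highest number of the two, so it is the weaker inhibitor; its nearest neighbour is compound 1, and the one known step, a 3.0-fold higher number from compound 1 to compound 2 (0.48 log units; beyond the scatter), reflects only an exchange on the acrylamide side chain.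

Compound 3 `COc1ccc(Nc2nc(Oc3cccc(NC(=O)/C=C/C(C)C)c3)c3sccc3n2)cn1` is not yet measured. It differs from compound 2 by 6-methoxypyridin-3-yl in place of 3-methoxyphenyl on a nitrogen on an aromatic ring. Among the compounds with values here, this change touches the aromatic ring on the amine nitrogen, a part of the molecule that the single measured step leaves untouched. Within the data shown here, no step therefore bears on it, and the data give no footing for a shift in either direction.

On that basis compound 3 is expected to land close to compound 2, with an estimated step of a 1.1-fold lower number from compound 2 to compound 3 (0.04 log units; within the scatter), none beyond the scatter. The estimate for compound 3 is 40000 nM, within a range from 12000 nM to 130000 nM.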

Compound 3, half-maximal inhibitory concentration: > 50000 nM
Compound 3 was reported as a limit; the forecaster's own chance of this, stated with the estimate: 30%; at least 1.2-fold (0.09 log units) between middle value and limit.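

Compounds 1 and 2 both carry 3-methoxyphenyl on the amine nitrogen, so compound 3 gives the only view shown of a change at this place, and the outcome is a ceiling on reading rather than a measured potency. In this assay compound 3 gives > 50000 nM, and that value is a limit of the assay, not a number. The exchange of 3-methoxyphenyl for 6-methoxypyridin-3-yl can therefore be read only as a floor, an at least 1.1-fold higher number from compound 2 to compound 3 (0.05 log units; that floor lies within the scatter), which shows no gain in potency from this ring but does not establish a loss, and one compound of the series now sits at the end of the reported range: the limit of > 50000 nM in this assay, at which 1 of the 3 values shown sits.

The compounds shown leave open how far compound 3 truly lies from compound 2, and whether the ring nitrogen or the methoxy group matters more for the outcome. A plain phenyl on the amine nitrogen, or a pyridine ring carrying a dimethylamino group in place of methoxy, would help to separate these two parts of the change.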